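This account rests on a few compounds, and the source may have more. Where it says the series, first, only, none or still open, it means among the compounds named here.

Compound 1 `CCN1CCc2cc(Br)cc(C(c3ccc(F)cc3)n3ccnc3)c21` and compound 2 `CCn1ccc2cccc(C(c3ccc(F)cc3)n3ccnc3)c21` share one core. In an assay for inhibition of Aromatase (Homo sapiens), using microsomes (a higher number here means a weaker inhibitor, a lower number a stronger inhibitor), compound 1 gives 90 nM; in this assay compound 2 gives 62 nM. Compound 2 carries the lower of the two numbers, but the gap to compound 1 is within the scatter, so neither is set apart. Compound 3 `CCn1ccc2cccc(C(c3cccc(Cl)c3)n3ccnc3)c21` has not yet been measured. Relative to compound 2 it differs only by 3-chlorophenyl in place of 4-fluorophenyl on a saturated chain carbon bound to an aromatic carbon and an aromatic nitrogen. Going by the values given here, no measured pair shows a step of this kind, so a step of a 1.3-fold higher number from compound 2 to compound 3 (0.11 log units; within the scatter) is expected, no larger than the scatter. Compound 3 is estimated at 80 nM, with a range from 25 nM to 250 nM.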

Compound 3, half-maximal inhibitory concentration: 170 nM
Estimate against measurement, compound 3: 2.1-fold (0.33 log units) below, within the range that was stated.
By their numbers in this assay, from the lowest: compounds 2, 1 and 3 (each within the scatter of the next, the first and the last beyond it).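

Going by these compounds alone, the aryl group on the saturated chain carbon bound to an aromatic carbon and an aromatic nitrogen matters in this assay: 3-chlorophenyl in place of 4-fluorophenyl gives a 2.7-fold higher number from compound 2 to compound 3 (0.44 log units; beyond the scatter), the only step so far and a modest one. This change alters the halogen and its ring position together, and the two contributions cannot be separated here. No measurement at hand accounts for the step.

Open, going by these compounds, is how an unsubstituted phenyl would read at this position. Also open, on these data alone, is whether a methoxy group or a nitrile on the aryl ring would keep the number near that of compound 2.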